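This account rests on a few compounds, and the source may have more. Where it says the series, first, only, none or still open, it means among the compounds named here.

Measured so far in an ADME assay on the whole organism (strain Wistar) for pharmacokinetics, with Rattus norvegicus as the target, given by the intravenous route (on this read-out higher numbers stand for fast clearance and lower numbers for slow clearance), as follows
compound 1 `CC[C@@H](c1ccc(C(=O)O)c(Oc2cccc(Cl)c2)c1F)N1CCC[C@H](n2cc(C)c(=O)[nH]c2=O)C1` stands at "not determined" (no result reported) with no number to compare
compound 2 `Cc1cn([C@H]2CCCN([C@@H](CC(C)C)c3ccc(C(=O)O)c(Oc4cccc(Cl)c4)c3F)C2)c(=O)[nH]c1=O` stands at 38 mL/min/kg as the single measured clearance

Among the measured compounds shown here, with 38 mL/min/kg compound 2 holds the only number, so it has no rank against any other compound. Compound 3 `CCC[C@@H](c1ccc(C(=O)O)c(Oc2cccc(Cl)c2)c1F)N1CCC[C@H](n2cc(C)c(=O)[nH]c2=O)C1` is still unmeasured. It differs from compound 2 in one place, by hydrogen in place of methyl on a saturated chain carbon bound to two saturated chain carbons, which is hydrogen in place of methyl on a saturated chain carbon bound to two saturated chain carbons and reads as isobutyl to propyl. For the measured compounds named here, the series holds no step between measured compounds, so the data give no direct measure of what this change does in this assay. The expectation is therefore no shift beyond the scatter, in either direction. The estimated step runs a 1.1-fold lower number from compound 2 to compound 3 (0.02 log units; within the scatter) and is expected to stay within the usual scatter. For compound 3 the expected clearance is estimated at 36 mL/min/kg with an expected range from 18 mL/min/kg to 70 mL/min/kg in this assay once the measurement is in.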

Compound 3, clearance: 18 mL/min/kg
Beside the measured number, compound 3's estimate is 2.0-fold (0.30 log units) above it; the range from low to high includes it.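

In this assay, the change from isobutyl to propyl gives a 2.1-fold lower number from compound 2 to compound 3 (0.32 log units; beyond the scatter), a modest step but the first measured effect in the series. It shows that clearance responds to this side chain: a methyl on a saturated chain carbon bound to two saturated chain carbons cannot be treated as a silent point of variation, even though the swap for hydrogen alters no ring, hydrogen-bond donor or acceptor count, or net charge. Nothing measured here explains the shift, so the step stands as an observation about this one matched pair.

Going by these compounds, a single step gives a direction for this pair only and cannot define a relationship between the side chain and clearance, so it remains open whether a butyl chain, a cyclopropylmethyl group or a chain ending in a hydroxyl group would follow the same direction. Also open, on these data alone, is whether hydrogen in place of methyl at this place would give a step of similar size with a different group in place of the carboxylic acid or the chlorophenyl ether of the shared core.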